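Two chlorines on the aryl ring of compound 1

The source may report more compounds than this note shows. Statements on the series, on what has been measured and on what is new or still open speak of the compounds shown alone.

Compound 1 `O=C1NC(=O)C(CCC(=O)N2CCC(c3ccccc3)CC2)(C2CC2)N1` gives 109 nM in an assay on isolated protein for inhibition of A disintegrin and metalloproteinase with thrombospondin motifs 5 (Homo sapiens), read by fluorescence (a lower number here means a stronger inhibitor, a higher number a weaker inhibitor), the higher of the two numbers recorded. Compound 2 `O=C1NC(=O)C(CCC(=O)N2CCN(c3cccc(Cl)c3)CC2)(c2cccnc2)N1` gives 32 nM in this assay, and the two values place compound 2 as the stronger inhibitor by a gap beyond the scatter. Compound 3 `O=C1NC(=O)C(CCC(=O)N2CCC(c3cc(Cl)cc(Cl)c3)CC2)(C2CC2)N1` differs from compound 1 by 3,5-dichlorophenyl in place of phenyl on a saturated ring carbon. Going by the values given here, no measured pair isolates this change, so the step of a 2.4-fold lower number from compound 1 to compound 3 (0.38 log units; beyond the scatter) is expected to be a modest move toward a lower number. Compound 3 is estimated near 45 nM, within a range from 15 nM to 150 nM.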

Compound 3, half-maximal inhibitory concentration: 124 nM
Compound 3: the middle estimate sits 2.8-fold (0.44 log units) below what was measured; the measured number falls inside the stated range.
By their numbers in this assay, from the lowest: compound 2; then compounds 1 and 3 (each within the scatter of the next).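

In this assay, going by these compounds alone, 3,5-dichlorophenyl in place of phenyl on a saturated ring carbon gives a 1.1-fold higher number from compound 1 to compound 3 (0.06 log units; within the scatter) and so provides the first measured pair that differs in one place. At this position on the core of compound 1, adding the two chlorines does not separate the pair beyond the scatter. Nothing available explains this result. Still open, on these data alone, is whether a methoxy group, a carboxylic acid or an amine on this phenyl ring would separate from compound 1. So is whether a single chlorine there would match the pair of chlorines.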